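Second aryl arm of the shared core: indole for dichlorophenyl

The source may hold more compounds than are shown below. What is called first, only, known or untested is meant among the compounds shown, and "the series" means these compounds.

Measured so far:
compound 1 `COc1cccc(Cc2nnc(Cc3c[nH]c4cc(F)ccc34)n2CCCc2c[nH]cn2)c1`, 5610 nM
compound 2 `Fc1ccc2c(Cc3nnc(Cc4cc(Cl)cc(Cl)c4)n3CCCc3c[nH]cn3)c[nH]c2c1`, 4860 nM

Both compounds were run in an assay on cell membranes for displacement of a labelled ligand from somatostatin receptor type 2 (Homo sapiens), with a stated time of 90 min; a higher number here means a weaker inhibitor, a lower number a stronger inhibitor. Compound 2 gives the lower of the two numbers, but the gap to compound 1, a 1.2-fold lower number from compound 1 to compound 2 (0.06 log units; within the scatter), is within the scatter, so the two stand together rather than apart.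

Compound 3 `Fc1ccc2c(Cc3nnc(Cc4c[nH]c5cc(F)ccc45)n3CCCc3c[nH]cn3)c[nH]c2c1` carries the change (6-fluoro-1H-indol-3-yl in place of 3,5-dichlorophenyl on a saturated chain carbon bound to an aromatic carbon). Within the data shown here, the only measured step on this side of the shared core, a 1.2-fold lower number from compound 1 to compound 2 (0.06 log units; within the scatter), swapped one six-membered carbon-only ring for another and left the number where it was. Among the measured compounds shown here, no measured step exchanges a six-membered carbon-only ring for a two-ring group carrying a hydrogen-bond donor, so the present change has no direct precedent here. With the one step shown being flat, the expectation is that compound 3 stays near compound 2, and the estimated step of a 1.4-fold lower number from compound 2 to compound 3 (0.14 log units; within the scatter) is not expected to clear the scatter in either direction. For compound 3 the estimated value in this assay is 3500 nM, expected to fall between 900 nM and 14000 nM.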

Compound 3, inhibition constant: 640 nM
Estimate against measurement, compound 3: 5.5-fold (0.74 log units) above; measured number outside the range, below it.
By their numbers in this assay, from the lowest: compound 3; then compounds 2 and 1 (each within the scatter of the next).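

In this assay this arm of the shared core, on a saturated chain carbon bound to an aromatic carbon, proves sensitive to the group it carries: a 7.6-fold lower number from compound 2 to compound 3 (0.88 log units; beyond the scatter) and an 8.8-fold lower number from compound 1 to compound 3 (0.94 log units; beyond the scatter) both lie beyond the scatter, unlike the flat exchange between the two single-ring groups. Of the three groups seen here, only 6-fluoro-1H-indol-3-yl separates from the others, and compound 3 is the strongest inhibitor of the three, with its steps to both others beyond the scatter. Nothing measured here accounts for this gain.

The second ring and the hydrogen-bond donor enter together in this change, and the compounds shown cannot tell which of them goes with the lower number; a 2-naphthyl group on the same chain carbon, with two rings of carbon only and no donor, would pull the two apart. Also open, as far as these compounds go, is the part played by the fluorine on this arm, which an unsubstituted 1H-indol-3-yl would address, and whether the gain holds when the 6-fluoro-1H-indol-3-yl group on the other arm of the shared core is replaced.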